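Morpholine amide replaces pyrrolidine amide on the ester side chain

The compounds below may be only part of what the source reports. "The series", "measured", "known", "first", "only" and "open" are said of these compounds alone.

For the measured compounds named here, in an ADME assay (liver) for pharmacokinetics, with Liver microsome (Rattus norvegicus) as the target, using microsomes (on this read-out lower numbers stand for a shorter-lived compound and higher numbers for a longer-lived compound), compound 2 `CCOc1cc(NC(=O)C2(NC(=O)c3ccc4c(C5CCCC5)c(-c5ncc(Cl)cn5)n(C)c4c3)CCC2)ccc1/C=C/C(=O)OCC(=O)N1CCCC1` gives 1.47 h, the higher of the two numbers known so far; compound 1 `CCCOC(=O)/C=C/c1ccc(NC(=O)C2(NC(=O)c3ccc4c(C5CCCC5)c(-c5ncc(Cl)cn5)n(C)c4c3)CCC2)cc1OCC` gives 0.35 h, and the difference is a 4.2-fold higher number from compound 1 to compound 2 (0.62 log units; beyond the scatter). Compound 3 `CCOc1cc(NC(=O)C2(NC(=O)c3ccc4c(C5CCCC5)c(-c5ncc(Cl)cn5)n(C)c4c3)CCC2)ccc1/C=C/C(=O)OCC(=O)N1CCOCC1` carries morpholin-4-yl in place of pyrrolidin-1-yl on a carbonyl carbon. Going by the values given here, no measured step swaps one amine on this carbonyl for another, so nothing measured bears directly on this change, and the single known step concerns a different group. Compound 3 is therefore expected to stay within the scatter of compound 2, the expected step being a 1.1-fold lower number from compound 2 to compound 3 (0.02 log units; within the scatter). The estimated value of compound 3 is 1.4 h, between 0.6 h and 3.2 h.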

Compound 3, half-life: 0.733 h
Compound 3: the middle estimate sits 1.9-fold (0.28 log units) above what was measured; the range from low to high includes it.
By their numbers in this assay, from the lowest: compound 1; then compounds 3 and 2 (each within the scatter of the next).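

In this assay, morpholin-4-yl in place of pyrrolidin-1-yl on a carbonyl carbon gives a 2.0-fold lower number from compound 2 to compound 3 (0.30 log units; within the scatter) and so stays within the scatter, which leaves the two amides unresolved on this read-out. Against ethyl on the saturated chain carbon, (morpholin-4-yl)carbonyl gives a 2.1-fold higher number from compound 1 to compound 3 (0.32 log units; beyond the scatter) as a step beyond the scatter, so this separation is not confined to the pyrrolidine amide. Nothing available explains these numbers. As far as these compounds go, whether an open-chain amine such as dimethylamine, or piperidine, on the same carbonyl carbon would give a similar half-life remains open.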